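The source may report more compounds than this note shows. Statements on the series, on what has been measured and on what is new or still open speak of the compounds shown alone.

Three compounds share one core and differ only in the aromatic ring attached to it. Compound 1 `O=C(O)Cc1sc(C(c2ccc(F)cc2)c2ccc(F)cc2)nc1-c1cccc(F)c1` gives 18 nM in an in vitro functional assay on HEK285-7 cells for antagonist activity at prostaglandin D2 receptor 2 (Homo sapiens), read by BRET and beta-arrestin recruitment; on this read-out lower numbers stand for stronger inhibition and higher numbers for weaker inhibition. Compound 2 `O=C(O)Cc1sc(C(c2ccc(F)cc2)c2ccc(F)cc2)nc1-c1ccoc1` gives 130 nM in the same assay, and compound 3 `O=C(O)Cc1sc(C(c2ccc(F)cc2)c2ccc(F)cc2)nc1-c1ccnc(F)c1` gives 4.7 nM. Compound 3 therefore has the lowest number of the three: the step of a 3.8-fold lower number from compound 1 to compound 3 (0.58 log units; beyond the scatter) and the step of a 28-fold lower number from compound 2 to compound 3 (1.44 log units; beyond the scatter) both point toward stronger inhibition, while a 7.2-fold higher number from compound 1 to compound 2 (0.86 log units; beyond the scatter) goes the other way.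

Compound 4 `CN(C)c1cc(-c2nc(C(c3ccc(F)cc3)c3ccc(F)cc3)sc2CC(=O)O)ccn1` is not yet measured. It differs from compound 3 by dimethylamino in place of fluoro on an aromatic carbon. Going by the values given here, none of the measured steps touches this position: the three steps all exchange the whole aromatic ring, and no pair shows what a change of one group on that ring does. The expectation can rest only on compound 3 keeping most of its potency, so a step near the scatter, or somewhat weaker, is expected, written as a 1.7-fold higher number from compound 3 to compound 4 (0.23 log units; within the scatter). For compound 4 the estimate is 8 nM, with a range from 2 nM to 40 nM.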

Compound 4, half-maximal inhibitory concentration: > 100000 nM
Compound 4 ended at the assay's limit (the forecaster's own chance of this, stated with the estimate: 0%); at least 12000-fold (4.09 log units) between middle value and limit.
By their numbers in this assay, from the lowest: compound 3; then compound 1; then compound 2. At a limit, above all of these: compound 4.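

For compound 4 the reading is a limit of this assay, not a number: the limit of > 100000 nM in this assay, at which 1 of the 4 values shown sits. The earlier steps shown here exchanged the whole aromatic ring, whereas this single exchange on the ring, an at least 21000-fold higher number from compound 3 to compound 4 (4.32 log units; beyond the scatter), shows that the position next to the ring nitrogen can decide between strong inhibition and none detectable in this read-out. The 2-(dimethylamino)pyridin-4-yl ring also falls far behind the other two rings, with an at least 760-fold higher number from compound 2 to compound 4 (2.88 log units; beyond the scatter) and an at least 5500-fold higher number from compound 1 to compound 4 (3.74 log units; beyond the scatter), so a ring that differs from the best one by a single group can rank below even the furan-3-yl compound.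

On these data alone, whether the loss is specific to dimethylamino stays open, since a plain amine, a methylamino or a methoxy group at this place could give a different answer. The compounds shown also leave open what hydrogen or chloro in place of fluoro would do.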